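The source may hold more compounds than are shown below. What is called first, only, known or untested is meant among the compounds shown, and "the series" means these compounds.

Measured in a functional assay on PC-3 cells (Homo sapiens) for antiproliferative activity, read by MTT assay, with a stated time of 72 h; a lower number here means a stronger inhibitor, a higher number a weaker inhibitor:

compound 1 `C#CCSc1nc(Sc2nnnn2CCN(C)C)c(C#N)c(-c2ccc(Cl)cc2)n1`: 7170 nM
compound 2 `C#CCSc1nc(Sc2nc(C)c(C)s2)c(C#N)c(-c2cc(OC)c(OC)c(OC)c2)n1`: > 20000 nM

The result for compound 2 is a limit of the assay and not a number: compound 2 stands at > 20000 nM. For the measured compounds named here, the only numerical value in this assay belongs to compound 1, at 7170 nM. Compound 3 `C#CCSc1nc(Sc2ccccn2)c(C#N)c(-c2cc(OC)c(OC)c(OC)c2)n1` has not yet been measured. It differs from compound 2 in one place, with pyridin-2-yl in place of 4,5-dimethyl-1,3-thiazol-2-yl on a sulfur. Going by the values given here, no measured pair shows this change. Among the compounds with values here, a small shift towards stronger inhibition is expected, and it may not exceed the usual scatter, with compound 1 at 7170 nM as the only guide to how far it might reach. The expected change is an at least 1.2-fold lower number from compound 2 to compound 3 (0.09 log units; that floor lies within the scatter). For compound 3 the estimated value is 16000 nM, with an expected range of 6000 nM to 40000 nM.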

Compound 3, half-maximal inhibitory concentration: > 10000 nM
Compound 3: a limit, no number; the forecaster's own chance of this, stated with the estimate: 50%; the middle value is on the limit's open side.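

Compound 2 and compound 3 both gave limits of the assay and not numbers, so no step can be read between them. The compounds shown leave open whether pyridin-2-yl or 4,5-dimethyl-1,3-thiazol-2-yl on that sulfur gives the stronger inhibitor.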